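This account rests on a few compounds, and the source may have more. Where it says the series, first, only, none or still open, it means among the compounds named here.

Compound 1 `COc1ccc(-c2nc3c(c(C)nn3-c3ccccc3)c(-c3ccccc3O)c2C#N)cc1`: > 23000 nM
Compound 2 `CCc1ccc(-c2nc3c(c(C)nn3-c3ccccc3)c(-c3ccccc3OC)c2C#N)cc1`: > 20000 nM
Compound 3 `CCc1ccc(-c2nc3c(c(C)nn3-c3ccccc3)c(-c3ccccc3C(=O)OC)c2C#N)cc1`: > 20000 nM

All three entries are limits, not numbers. In an ADME assay on BJ cells (Homo sapiens) for cytotoxicity, with a stated time of 72 h (a lower number here means that less compound is needed, a higher number that more compound is needed for the effect), compound 1 gives > 23000 nM, so its place is the limit of > 23000 nM in this assay, at which 1 of the 3 values shown sits. The other two compounds stand at the limit of > 20000 nM in this assay, at which 2 of the 3 values shown sit.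

Compound 4 `CCCc1ccc(-c2nc3c(c(C)nn3-c3ccccc3)c(-c3ccccc3O)c2C#N)cc1` has propyl in place of methoxy on an aromatic carbon, the change from 4-methoxyphenyl to 4-propylphenyl: propyl in place of methoxy on an aromatic carbon.

Among the compounds with values here, the only measured step, a step that the two limits leave unreadable from compound 2 to compound 3, lies elsewhere in the molecule and gives no usable size. With every known value in this assay a limit, no shift beyond the usual scatter is expected. The expected step is a number no higher from compound 1 to compound 4 (the limit leaves the size open). Compound 4 is estimated at 23000 nM, within an expected range of 12000 nM to 40000 nM.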

Compound 4, half-maximal effective concentration: 22500 nM
Estimate against measurement, compound 4: 1.0-fold (0.01 log units) above; measured number inside the range.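

In this assay, within the data shown here, compound 4 gives 22500 nM, the first real number rather than a limit. Propyl in place of methoxy on this aromatic carbon gives an at least 1.0-fold lower number from compound 1 to compound 4 (0.00 log units; that floor lies within the scatter). The value of compound 1 is a limit, so this step has only a floor and its full size cannot be read.

On these data alone, whether an amine or a carboxylic acid on this carbon would give a clearly different number stays open. So does the effect of a chain longer than propyl.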